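A few compounds are considered here, and "the series" means these few. Any claim that something is new, unique, unknown or untested is made for them only; others in the source may bear on it.

In an ADME assay on L02 cells (Homo sapiens) for antiproliferative activity, read by MTT assay, with a stated time of 48 h (on this read-out higher numbers stand for weaker inhibition and lower numbers for stronger inhibition), compound 1 `N#CC1=C(N)Oc2c(N)cc3nc4ccccc4nc3c2C12C(=O)N(Cc1cnnn1-c1cccc(C(F)(F)F)c1)c1ccccc12` gives 38100 nM. Compound 2 `COc1ccc(-n2nncc2CN2C(=O)C3(C(C#N)=C(N)Oc4c(N)cc5nc6ccccc6nc5c43)c3ccccc32)cc1`, which carries 4-methoxyphenyl in place of 3-(trifluoromethyl)phenyl on an aromatic nitrogen, is reported in this assay only as a limit, > 50000 nM, the line the limit of > 50000 nM in this assay, at which 1 of the 2 values shown sits, marking where it stands. The step of an at least 1.3-fold higher number from compound 1 to compound 2 (0.11 log units; that floor lies within the scatter) thus has a floor that sits within the scatter, and compound 2 stands at the assay limit rather than at a measured number. Compound 3 `N#CC1=C(N)Oc2c(N)cc3nc4ccccc4nc3c2C12C(=O)N(Cc1cnnn1-c1c(F)cccc1F)c1ccccc12` differs from compound 2 by 2,6-difluorophenyl in place of 4-methoxyphenyl on an aromatic nitrogen. Among the measured compounds shown here, the one measured step, an exchange of one aryl group for another on the same aromatic nitrogen, was small, so it bears on this change only loosely, and no step beyond the scatter is expected in this assay. Compound 3 is therefore estimated at 45000 nM, between 20000 nM and 100000 nM. The expected step of an at least 1.1-fold lower number from compound 2 to compound 3 (0.04 log units; that floor lies within the scatter) amounts to nothing beyond the scatter.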

Compound 3, half-maximal inhibitory concentration: > 50000 nM
Compound 3 gave a limit, no number (the forecaster's own chance of this, stated with the estimate: 50%); middle value at least 1.1-fold (0.04 log units) from the limit.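

In this assay compound 3 is again only a limit, > 50000 nM, so a second aryl group on this aromatic nitrogen, 2,6-difluorophenyl, joins 4-methoxyphenyl at the limit of the assay: the limit of > 50000 nM in this assay, at which 2 of the 3 values shown sit. Set against the only compound with a number, 2,6-difluorophenyl in place of 3-(trifluoromethyl)phenyl gives an at least 1.3-fold higher number from compound 1 to compound 3 (0.11 log units; that floor lies within the scatter), so this exchange, like the earlier one, shows no step beyond the scatter. Compound 2 and compound 3 both stand as limits, and the step that joins them cannot be read.

On these data alone, how far the true values of compound 2 and compound 3 lie past the limit remains open. The compounds shown carry only a substituted phenyl on this nitrogen, so it also remains open how this assay would respond to an unsubstituted phenyl, a benzyl group or an alkyl chain ending in an amine at the same place.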